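This account rests on a few compounds, and the source may have more. Where it says the series, first, only, none or still open, it means among the compounds named here.

Of the compounds shown here, three of a shared core have been measured in an assay on isolated protein for inhibition of aldehyde dehydrogenase 1A1 (Homo sapiens), read by spectrophotometry, tested at 10 uM; a lower number here means less inhibition, a higher number more inhibition at the concentration tested (going by the name of the read-out). Compound 1, `Cc1cccc(Cn2c(CN3CCN(C(=O)c4ccc([N+](=O)[O-])cc4)CC3)nc3ccccc32)c1`, gives 24.3% in this assay. Compound 2, `Cc1cccc(Cn2c(OC3CCN(C(=O)c4ccco4)CC3)nc3ccccc32)c1`, gives 68.3%, and compound 3, `O=C(C1CC1)N1CCN(Cc2nc3ccccc3n2Cc2ccccc2C(F)(F)F)CC1`, gives 56.3%. Among these three numbers compound 1 stands lowest: compound 3 is its nearest neighbour, with a number beyond the scatter above it, and compound 2 lies furthest, also beyond the scatter above it.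

Compound 4, `CC(=O)N1CCN(Cc2nc3ccccc3n2Cc2cccc(C)c2)CC1`, is the compound whose number is not yet known. Compared with compound 1 it differs in one place: methyl in place of 4-nitrophenyl on a carbonyl carbon. The amide-type nitrogen in a ring and the carbonyl carbon are kept; only the group on that carbonyl carbon changes, from (4-nitrophenyl)carbonyl to acetyl.

Going by the values given here, no pair of measured compounds differs in exactly this way, so the size of the step cannot be read from a measured step. The other two measured compounds both carry smaller groups on the carbonyl carbon than compound 1 does and both give higher numbers, so a rise in this assay is expected for compound 4, of moderate size, though the scatter of such measurements leaves room for no change at all. Compound 4 is therefore estimated at 40%, within 15% to 65%, an expected step of a number 15.7 percentage points higher from compound 1 to compound 4 (beyond the scatter).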

Compound 4, a percentage reported as inhibition, at one concentration (the size of the read-out at that concentration, not a potency): 70.3%
The estimate for compound 4 lay 30.3 percentage points below the measured number, and the stated range ends below it.
By their numbers in this assay, from the lowest: compound 1; then compound 3; then compounds 2 and 4 (each within the scatter of the next).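

In this assay, replacing 4-nitrophenyl with methyl on the carbonyl carbon gives a number 46 percentage points higher from compound 1 to compound 4 (beyond the scatter), a large step and the only one shown between compounds that differ in one place. It shows that the group on this carbonyl carbon can by itself move the read-out well beyond the scatter, with the amide-type nitrogen in a ring, the carbonyl and the rest of the core of compound 1 kept. Nothing measured here bears on what lies behind the step.

Going by these compounds alone, this single step joins only two ends of the change, so it remains open whether a phenyl without the nitro group, an ethyl or a longer chain on this carbonyl carbon would fall near compound 1 or near compound 4, and thus whether the step belongs to the ring, to the nitro group or to both. As far as these compounds go, it is also open whether the change would give a similar step on a different core, as compound 2 and compound 3 each differ from compound 1 in more than one place and offer no second reading of it.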